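The source may report more compounds than this note shows. Statements on the series, on what has been measured and on what is new or still open speak of the compounds shown alone.

Measured so far:
- compound 1 `O=C(CN1CCN(c2nnc(Cc3ccccc3)c3ccccc23)CC1)Nc1c(F)cccc1F`: 84500 nM
- compound 2 `O=C(CN1CCN(c2nnc(Cc3ccccc3)c3ccccc23)CC1)Nc1ccc(Br)cc1`: 2000 nM
- compound 3 `O=C(CN1CCN(c2nnc(Cc3ccncc3)c3ccccc23)CC1)Nc1ccc(F)c(Cl)c1`: 12300 nM

Compound 1 stands highest of the three numbers in a functional assay on A549 cells (Homo sapiens) for cytotoxicity, read by MTT assay, with a stated time of 72 h; on this read-out lower numbers stand for stronger inhibition and higher numbers for weaker inhibition. Compound 3 sits nearest to it, and the gap from compound 1 to compound 3 is beyond the scatter, while compound 2 sits furthest off; compound 3 also carries a different group on the shared core, so its value is read only on its own.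

Compound 4 `O=C(CN1CCN(c2nnc(Cc3ccccc3)c3ccccc23)CC1)Nc1cccc(F)c1` is not yet measured. It differs from compound 1 by 3-fluorophenyl in place of 2,6-difluorophenyl on an amide-type nitrogen.

Within the data shown here, one measured step bears on this: a 42-fold lower number from compound 1 to compound 2 (1.63 log units; beyond the scatter). That step also replaced the 2,6-difluorophenyl on the amide-type nitrogen and gave a large drop in the number. Among the measured compounds shown here, the group entering here, 3-fluorophenyl, is not the same as the 4-bromophenyl of compound 2, so the size of that step cannot simply be carried over, but the direction is the only guide available and points downward.

For compound 4 the expectation is therefore a lower number than compound 1, estimated as a 9.4-fold lower number from compound 1 to compound 4 (0.97 log units; beyond the scatter). The estimated value for compound 4 is 9000 nM, with an expected range from 2000 nM to 40000 nM.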

Compound 4, half-maximal inhibitory concentration: 130000 nM
Beside the measured number, compound 4's estimate is 14-fold (1.16 log units) below it, outside the stated range (above it).
By their numbers in this assay, from the lowest: compound 2; then compound 3; then compounds 1 and 4 (each within the scatter of the next).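

In this assay, 3-fluorophenyl in place of 2,6-difluorophenyl on the amide-type nitrogen gives a 1.5-fold higher number from compound 1 to compound 4 (0.19 log units; within the scatter), so compounds 1 and 4 cannot be told apart on this read-out despite the change in the group. Leaving 2,6-difluorophenyl is therefore not enough on its own to give the large drop seen earlier with compound 2. That drop goes with the entry of 4-bromophenyl specifically, as the comparison at the same place shows: a 65-fold higher number from compound 2 to compound 4 (1.81 log units; beyond the scatter), which leaves compound 2 apart from both fluorinated members. No evidence shown here accounts for this gap.

Still open, from the compounds shown here alone, is whether the bromine itself or its place on the ring sets compound 2 apart, a question that an unsubstituted phenyl or a chlorine-bearing phenyl on the same nitrogen would help to settle. Also open, going by these compounds, is whether this position tolerates anything other than a substituted phenyl, such as a cyclohexyl group or a phenyl carrying a carboxylic acid or an amine.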